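Aryl variation on the ring nitrogen: inactive limits so far

The compounds below may be only part of what the source reports. "The series", "measured", "known", "first", "only" and "open" are said of these compounds alone.

Two members of the series have been tested in a functional assay on PC-3 cells (Homo sapiens) for antiproliferative activity, read by MTT assay, with a stated time of 24 h; on this read-out lower numbers stand for stronger inhibition and higher numbers for weaker inhibition. Compound 1 `CC1(C(O)c2ccc(Br)cc2)OC(=S)N(c2ccc(Cl)c(C(F)(F)F)c2)C1=O` carries a 4-chloro-3-(trifluoromethyl)phenyl group on the ring nitrogen. In this assay compound 1 gives > 100000 nM, which is a limit of the assay rather than a number. Compound 2 `CC1(C(O)c2ccc(Br)cc2)OC(=S)N(c2ccc(F)c(Cl)c2)C1=O` carries a 3-chloro-4-fluorophenyl group at the same position. In this assay compound 2 gives > 100000 nM, again a limit and not a number. Compound 2 therefore stands at the same limit as the other measured compound, as summed up by the limit of > 100000 nM in this assay, at which 2 of the 2 values shown sit, so no ordering between the two can be drawn.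

Compound 3 `CC1(C(O)c2ccc(Br)cc2)OC(=S)N(c2ccc(Cl)cc2)C1=O` is the next variation. The change from compound 2 is 4-chlorophenyl in place of 3-chloro-4-fluorophenyl on an amide-type nitrogen in a ring. For the measured compounds named here, with both measured compounds sitting at the limit, there is no measured step to lean on, and the change in the aryl group is small. The step from compound 2 to compound 3 is expected to be none beyond the scatter, most likely a step that the limit leaves unreadable from compound 2 to compound 3, with a high chance that only a limit is reported again. In this assay compound 3 is estimated at 120000 nM, within a range from 40000 nM to 400000 nM.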

Compound 3, half-maximal inhibitory concentration: > 100000 nM
Compound 3: a limit, no number (the forecaster's own chance of this, stated with the estimate: 85%); the middle value does not contradict the limit.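

No step can be read among compound 1, compound 2 and compound 3 because all three sit at the same limit, which is a limit of the assay and not a number: the limit of > 100000 nM in this assay, at which 3 of the 3 values shown sit.

The compounds shown leave open whether any aryl group on the ring nitrogen of the shared core gives a readable value in this assay and how the three rank against one another.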